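The compounds below may be only part of what the source reports. "The series", "measured", "known", "first", "only" and "open" are said of these compounds alone.

Measured compounds:
Compound 1, `O=C(Nc1cccc(-n2cc(-c3ccncc3)c(-c3ccc(Cl)c(O)c3)n2)c1)Nc1cccc(C(F)(F)F)c1`, in a functional assay on 786-0 cells (Homo sapiens) for inhibition, read by sulforhodamine B assay, with a stated time of 48 h; a lower number here means a stronger inhibitor of growth, a higher number a weaker inhibitor of growth: 4690 nM
Compound 2, `O=C(Nc1cccc(-n2cc(-c3ccncc3)c(-c3ccc(Cl)c(O)c3)n2)c1)Nc1ccc(Cl)c(Cl)c1`: 7220 nM
Compound 3, `COc1cc(-c2nn(-c3cccc(NC(=O)Nc4cccc(C(F)(F)F)c4)c3)cc2-c2ccncc2)ccc1Cl`: 1280 nM

Compound 1 stands second highest of the three numbers. Compound 2 lies nearest, with a 1.5-fold higher number from compound 1 to compound 2 (0.19 log units; within the scatter), and compound 3 furthest, with a 3.7-fold lower number from compound 1 to compound 3 (0.56 log units; beyond the scatter). Compound 4, `O=C(Nc1cccc(-n2cc(-c3ccncc3)c(-c3ccc(Cl)c(O)c3)n2)c1)Nc1cc(C(F)(F)F)cc(C(F)(F)F)c1`, differs from compound 1 by trifluoromethyl in place of hydrogen on an aromatic carbon. The step that bears on this change is the earlier exchange of the aryl group on the same amide-type nitrogen, a 1.5-fold higher number from compound 1 to compound 2 (0.19 log units; within the scatter), which stayed within the scatter. Compound 4 is therefore expected to show no step beyond the scatter, a 1.2-fold higher number from compound 1 to compound 4 (0.07 log units; within the scatter). Compound 4 is estimated at 5500 nM, with a range from 2000 nM to 14000 nM.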

Compound 4, concentration for 50% growth inhibition: 1170 nM
Compound 4: the middle estimate sits 4.7-fold (0.67 log units) above what was measured; the whole stated range lies above it.
By their numbers in this assay, from the lowest: compounds 4 and 3 (each within the scatter of the next); then compounds 1 and 2 (each within the scatter of the next).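

In this assay, trifluoromethyl in place of hydrogen on the aromatic ring of compound 1 gave a 4.0-fold lower number from compound 1 to compound 4 (0.60 log units; beyond the scatter), whereas the earlier exchange of that aryl group, a 1.5-fold higher number from compound 1 to compound 2 (0.19 log units; within the scatter), stayed within the scatter. This ring therefore responds to substitution at this place, and here the added group strengthens growth inhibition. Nothing available explains this step. As far as these compounds go, it remains open whether an amine or a carboxylic acid at the same place would act likewise, and whether this change would combine with the methyl on the oxygen in compound 3.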